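Methoxy for chloro on the anilino ring of compound 1

The source may hold more compounds than are shown below. What is called first, only, known or untested is meant among the compounds shown, and "the series" means these compounds.

Compound 1, `Clc1ccccc1Nc1nc(-c2ccncc2)cs1`, is the weaker of the two compounds with a single number in a functional assay on RCC4 cells (Homo sapiens) for inhibition, read by XTT assay, with a stated time of 4 days (on this read-out lower numbers stand for stronger inhibition and higher numbers for weaker inhibition), where compound 1 gives 28200 nM. Compound 3, `C#Cc1cnccc1-c1csc(Nc2cccc(C)c2)n1`, gives 1380 nM in this assay, a lower number than that of compound 1 and beyond the scatter. Compound 2, `Cc1cccc(Nc2cccc(-c3ccncc3)c2)c1`, has several entries in this assay, 36900 nM; 37200 nM (2 entries); the agreement of these entries, shown by the several entries of compound 2 in this assay, 36900 nM; 37200 nM (2 entries), indicates the repeatability of the read-out in this cell line.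

Compound 4, `COc1ccccc1Nc1nc(-c2ccncc2)cs1`, differs from compound 1 in one place: methoxy in place of chloro on an aromatic carbon. Within the data shown here, no step of this kind has been measured, so no measured change can be pointed to. The expectation is a step of no more than the usual scatter in this assay, in either direction, since the change is a small exchange of one substituent for another at the same place. Compound 4 is therefore estimated at 30000 nM, with a range from 10000 nM to 90000 nM. The step from compound 1 to compound 4 that this estimate means is a 1.1-fold higher number from compound 1 to compound 4 (0.03 log units; within the scatter).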

Compound 4, half-maximal inhibitory concentration: 33900 nM
Compound 4: middle estimate off by 1.1-fold (0.05 log units), on the low side; the measured number falls inside the stated range.
By their numbers in this assay, from the lowest: compound 3; then compounds 1 and 4 (each within the scatter of the next).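

In this assay, among these compounds, methoxy in place of chloro on an aromatic carbon ortho to a large group gives a 1.2-fold higher number from compound 1 to compound 4 (0.08 log units; within the scatter), the first step between compounds that differ in one place. At this place, then, an exchange that adds one hydrogen-bond acceptor and goes from one heavy atom to two leaves the number within the scatter. The read-out is repeatable enough in this cell line for such a small step to be read as no real difference: the several entries of compound 2 in this assay, 36900 nM; 37200 nM (2 entries).

Two substituents at one place cannot show whether the read-out stays unchanged for very different groups, such as an amine, a carboxylic acid or a longer alkoxy chain. On these data alone, whether methoxy for chloro gives a similar step on the core of compound 3 also remains open.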